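From bromo to iodo: compound 3 in prospect

The source may report more compounds than this note shows. Statements on the series, on what has been measured and on what is new or still open speak of the compounds shown alone.

Measured in a functional assay on SK-MEL-28 cells (Homo sapiens) for antiproliferative activity; on this read-out higher numbers stand for weaker inhibition and lower numbers for stronger inhibition:
- Compound 1 `O=C1NC(O)C(F)=CN1[C@H]1C=C[C@@H](CO)O1`: 21700 nM
- Compound 2 `Nc1nc(=O)n([C@H]2C=C[C@@H](CO)O2)cc1Br`: > 100000 nM

Compound 1 gives a number in this assay, 21700 nM. Compound 2 gives no number, and its > 100000 nM is a limit of the assay. Compound 2 therefore sits at the limit of > 100000 nM in this assay, at which 1 of the 2 values shown sits, and this is the only starting point for the next step.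

Compound 3 `Nc1nc(=O)n([C@H]2C=C[C@@H](CO)O2)cc1I` differs from compound 2 by iodo in place of bromo on an aromatic carbon, ortho to an amino group. For the measured compounds named here, no measured pair shows this exchange. No change beyond the scatter is expected in this assay, in either direction. The expected a number no higher from compound 2 to compound 3 (the limit leaves the size open) is an estimate only. For compound 3 the estimated value is 100000 nM, with an expected range of 40000 nM to 200000 nM.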

Compound 3, half-maximal inhibitory concentration: > 100000 nM
Compound 3 gave a limit, no number (the forecaster's own chance of this, stated with the estimate: 70%); the middle value sits exactly at the limit.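

Compound 2 and compound 3 both give only a limit, so no step can be read between them: the limit of > 100000 nM in this assay, at which 2 of the 3 values shown sit.

The compounds shown leave open how far either compound lies from that limit, and whether iodo in place of bromo on an aromatic carbon changes the read-out at all.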